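Methoxy added to two related cyclic thiourea and urea cores

The source may hold more compounds than are shown below. What is called first, only, known or untested is meant among the compounds shown, and "the series" means these compounds.

Compound 1, `S=C1NCCN1Cc1ccccc1`, in a functional assay on B16 cells (Mus musculus) for inhibition, with a stated time of 72 h (a lower number here means a stronger inhibitor, a higher number a weaker inhibitor), gives > 10000 nM, which is a limit of the assay.
Compound 2, `COc1ccc(CN2CCNC2=S)cc1`, in this assay gives > 10000 nM, also a limit.
Compound 3, `O=C1NCCCN1Cc1ccccc1`, in this assay gives > 10000 nM, again a limit.

From compound 1 to compound 2 the change is methoxy in place of hydrogen on an aromatic carbon, and the step is a step that the two limits leave unreadable from compound 1 to compound 2. The two limits together sit at the limit of > 10000 nM in this assay, at which 3 of the 3 values shown sit. The difference between the cores of compound 1 and compound 3 is not broken down here. Compound 4, `COc1ccc(CN2CCCNC2=O)cc1`, carries the same kind of change, (methoxy in place of hydrogen on an aromatic carbon), though its place is para to a group of 8 heavy atoms rather than 7. Since compound 3 gives only a limit, he expects a step that the limit leaves unreadable from compound 3 to compound 4 and estimates compound 4 at 15000 nM, most likely again reported as a limit.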

Compound 4, half-maximal inhibitory concentration: > 10000 nM
Compound 4 ended at the assay's limit; the forecaster's own chance of this, stated with the estimate: 85%; the middle value does not contradict the limit.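

In this assay, for the compounds shown here, compound 4 gives > 10000 nM, a limit of the assay, so no step from compound 3 to compound 4 can be read. The compounds shown leave open whether methoxy in place of hydrogen changes inhibition at all, and how strongly any of them inhibits: the limit of > 10000 nM in this assay, at which 4 of the 4 values shown sit.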